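A few compounds are considered here, and "the series" means these few. Any claim that something is new, unique, unknown or untested is made for them only; others in the source may bear on it.

Measured in a functional assay on DU-145 cells (Homo sapiens) for inhibition, read by MTT assay, with a stated time of 72 h; on this read-out lower numbers stand for stronger inhibition and higher numbers for weaker inhibition:
- compound 1 `O=C(O)CCCCCCC(=O)Nc1ccc(C2=C(c3ccc(O)cc3)C3CC(S(=O)(=O)Oc4cccc5ccccc45)C2O3)cc1`: 48600 nM
- compound 2 `Cc1ccccc1OS(=O)(=O)C1CC2OC1C(c1ccc(NC(=O)CCCCCCC(=O)O)cc1)=C2c1ccc(O)cc1`: > 100000 nM

Compound 2 reads > 100000 nM, which is a limit of the assay and not a number. It stands at the weak end of the two compounds, at the limit of > 100000 nM in this assay, at which 1 of the 2 values shown sits.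

Compound 3 `O=C(O)CCCCCCC(=O)Nc1ccc(C2=C(c3ccc(O)cc3)C3CC(S(=O)(=O)Oc4ccc(C(F)(F)F)cc4)C2O3)cc1` keeps the shared core and carries 4-(trifluoromethyl)phenyl in place of 2-methylphenyl on an oxygen.

Going by the values given here, only one measured step bears on this place, an at least 2.0-fold higher number from compound 1 to compound 2 (0.31 log units; beyond the scatter). It is at least modest and shows that the group on this oxygen can shift the number in this assay, but it says nothing direct about trifluoromethyl. A modest move toward lower numbers is therefore expected, and another result at the limit would be no surprise. The estimate amounts to an expected at least 1.4-fold lower number from compound 2 to compound 3 (0.15 log units; that floor lies within the scatter). Compound 3 is expected near 70000 nM, with an estimated range of 25000 nM to 140000 nM.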

Compound 3, half-maximal inhibitory concentration: 77000 nM
Compound 3: the middle estimate sits 1.1-fold (0.04 log units) below what was measured; the range from low to high includes it.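

Replacing 2-methylphenyl with 4-(trifluoromethyl)phenyl on this oxygen brings the read-out back to a measured number in this assay, with an at least 1.2-fold lower number from compound 2 to compound 3 (0.11 log units; that floor lies within the scatter). On these data alone, compound 2 reads > 100000 nM, which is a limit of the assay and not a number, so the true size of this step stays unknown and only its floor can be stated: the limit of > 100000 nM in this assay, at which 1 of the 3 values shown sits. Naphthalen-1-yl and 4-(trifluoromethyl)phenyl cannot be told apart here, with a 1.6-fold higher number from compound 1 to compound 3 (0.20 log units; within the scatter), so the larger naphthalen-1-yl group is not required for a measurable number at this position.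

The compounds shown leave open what a phenyl ring carrying an amine or a carboxylic acid would do on this oxygen, and whether a simple methyl group could replace the ring. They also leave open whether any group here can bring the number far lower.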